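This account rests on a few compounds, and the source may have more. Where it says the series, first, only, none or still open, it means among the compounds named here.

Working notes on the series, read in a functional assay on Jurkat cells (Homo sapiens) for antiproliferative activity, read by MTT assay, with a stated time of 72 h; on this read-out lower numbers stand for stronger inhibition and higher numbers for weaker inhibition. Compound 1 `COc1cc(C(=O)c2sc3ccccc3c2-c2ccccc2)cc(OC)c1OC` gives 1500 nM, and compound 2 `COc1cc(C(=O)c2sc3ccccc3c2-c2ccc(Cl)cc2)cc(OC)c1OC` gives 3700 nM. Compound 3 `COc1cc(C(=O)c2sc3ccccc3c2-c2ccc(SC)cc2)cc(OC)c1OC` gives 1900 nM, which falls within the span of the other two values and within the scatter of each: the steps are a 1.3-fold higher number from compound 1 to compound 3 (0.10 log units; within the scatter) and a 1.9-fold lower number from compound 2 to compound 3 (0.29 log units; within the scatter).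

Compound 4 `COc1ccc(-c2c(C(=O)c3cc(OC)c(OC)c(OC)c3)sc3ccccc23)c(OC)c1` is not yet measured. Its change is 2,4-dimethoxyphenyl in place of 4-(methylsulfanyl)phenyl on an aromatic carbon, on an aromatic carbon of a five-membered aromatic ring with 1 sulfur. For the measured compounds named here, no measured compound carries a 2,4-dimethoxyphenyl group, so only the other changes at this aromatic group offer guidance. Of these, only a 2.5-fold higher number from compound 1 to compound 2 (0.39 log units; beyond the scatter) exceeds the scatter, and it is modest. The change from chloro to methylsulfanyl, a 1.9-fold lower number from compound 2 to compound 3 (0.29 log units; within the scatter), does not exceed it.

In this assay, no step beyond the scatter is therefore expected, with a slight lean towards a higher number. The expected step is a 1.3-fold higher number from compound 3 to compound 4 (0.12 log units; within the scatter). For compound 4 the estimated value is 2500 nM, with an expected range of 900 nM to 7000 nM.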

Compound 4, half-maximal inhibitory concentration: 4000 nM
For compound 4 the middle estimate is 1.6-fold (0.20 log units) below the measured one; the measured number falls inside the stated range.
By their numbers in this assay, from the lowest: compounds 1, 3, 2 and 4 (each within the scatter of the next, the first and the last beyond it).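

In this assay, for the compounds shown here, 2,4-dimethoxyphenyl is the first group at this position with methoxy substituents, and it gives a 2.1-fold higher number from compound 3 to compound 4 (0.32 log units; beyond the scatter) and a 2.7-fold higher number from compound 1 to compound 4 (0.43 log units; beyond the scatter), both modest. Against 4-chlorophenyl there is a 1.1-fold higher number from compound 2 to compound 4 (0.03 log units; within the scatter), so 2,4-dimethoxyphenyl and 4-chlorophenyl cannot be told apart here, and no substituted group yet gives a number beyond the scatter below that of the plain phenyl in compound 1, while compound 2 and compound 4 lie beyond it above and compound 3 stays within it. Nothing available accounts for the step to 2,4-dimethoxyphenyl.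

Open, as far as these compounds go, is whether a single methoxy group on this phenyl would match 2,4-dimethoxyphenyl. Also open, from the compounds shown here alone, is how a phenyl bearing an amine or a carboxylic acid would read at this position.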